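Cyclohexyl for methoxymethyl on compound 3

A few compounds are considered here, and "the series" means these few. Any claim that something is new, unique, unknown or untested is made for them only; others in the source may bear on it.

In a physicochemical assay for lipophilicity, read by LC-MS, using the shake flask method, in phosphate buffer, with a stated time of 50 min, at pH 7.4 (a lower number here means a more polar compound, a higher number a more lipophilic compound), compound 3 (`COCC(=O)OCCCCCC(=O)N[C@H](C(=O)N1C[C@H](O)C[C@H]1C(=O)NCc1ccc(-c2scnc2C)cc1)C(C)(C)C`) gives 1.7, the second highest of the three numbers at hand. Compound 1 (`COCC(=O)NCCCCCC(=O)N[C@H](C(=O)N1C[C@H](O)C[C@H]1C(=O)NCc1ccc(-c2scnc2C)cc1)C(C)(C)C`) stands higher at 2.2, and compound 2 (`Cc1ncsc1-c1ccc(CNC(=O)[C@@H]2C[C@@H](O)CN2C(=O)[C@@H](NC(=O)CCCCCNC(=O)CC(c2ccccc2)c2ccccc2)C(C)(C)C)cc1`) stands lowest at 0.3.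

Compound 4 (`Cc1ncsc1-c1ccc(CNC(=O)[C@@H]2C[C@@H](O)CN2C(=O)[C@@H](NC(=O)CCCCCOC(=O)C2CCCCC2)C(C)(C)C)cc1`) carries cyclohexyl in place of methoxymethyl on a carbonyl carbon. Among the compounds with values here, the only measured step, a number 0.50 log units lower from compound 1 to compound 3 (beyond the scatter), is modest. It concerns ((methoxymethyl)carbonyl)oxy in place of ((methoxymethyl)carbonyl)amino, so it bears on this change only indirectly. Within the data shown here, no measured pair isolates a swap at this carbonyl carbon, and the expectation rests mainly on the counted change. Compound 2 at 0.3 against compound 1 at 2.2 shows a gap larger than that step, so the range is kept wide.

The expected step is upward and beyond the scatter: a number 1.00 log units higher from compound 3 to compound 4 (beyond the scatter). For compound 4 the estimated value is 2.7, with an expected range of 1.9 to 3.6.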

Compound 4, distribution coefficient: 1.1
Compound 4: middle estimate off by 1.60 log units, on the high side, and the stated range ends above it.
By their numbers in this assay, from the lowest: compound 2; then compound 4; then compound 3; then compound 1.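

In this assay, the swap at this carbonyl carbon gives a number 0.60 log units lower from compound 3 to compound 4 (beyond the scatter), so the larger all-carbon cyclohexyl group, with its six-membered ring and no hydrogen-bond acceptor, goes with a lower number than methoxymethyl on this ester. Both changes away from compound 1 now run the same way, and together they give a number 1.10 log units lower from compound 1 to compound 4 (beyond the scatter), a large step where the ester change alone was modest. No supporting measurement accounts for the direction of this step.

As far as these compounds go, whether the fall belongs to the ring or to the loss of the ether oxygen stays open, and an open-chain hexyl group on the same carbonyl carbon would separate the two. Also open, from the compounds shown here alone, is whether cyclohexylcarbonyl on the amide nitrogen of compound 1, or an amine on this carbonyl carbon, would move the number the same way.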